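This account rests on a few compounds, and the source may have more. Where it says the series, first, only, none or still open, it means among the compounds named here.

In a functional assay on A549 cells (Homo sapiens) for cytotoxicity, read by MTT assay, with a stated time of 48 h (on this read-out higher numbers stand for weaker inhibition and lower numbers for stronger inhibition), compound 1 (`C=CC(C)(O)CC[C@@H]1C(=C)CC[C@H](Br)[C@@]1(C)CCC(OC)C(C)(C)O`) gives > 100000 nM as a limit of the assay, not as a number. Compound 2 (`C=CC(C)(O)CC[C@@H]1C(=C)CC[C@H](Br)[C@@]1(C)CCC1OC1(C)C`) also stops at a limit, with > 100000 nM as its reading. The untested compound 3 (`C=CC(C)(O)CC[C@@H]1C(=C)CC[C@H](Br)[C@@]1(C)CCC(O)C(=C)C`) keeps the core of compound 1 and alters one side group: 1-hydroxy-2-methylprop-2-en-1-yl in place of 2-hydroxy-1-methoxy-2-methylpropyl on a saturated chain carbon, two bonds along the chain from a saturated ring carbon. Here 1-hydroxy-2-methylprop-2-en-1-yl takes the place of 2-hydroxy-1-methoxy-2-methylpropyl on a saturated chain carbon, two bonds along the chain from a saturated ring carbon. Among the measured compounds shown here, one measured step bears on this, at the same place: a step that the two limits leave unreadable from compound 1 to compound 2 in which 3,3-dimethyloxiran-2-yl replaces that same group. All the evidence so far is the limit of > 100000 nM in this assay, at which 2 of the 2 values shown sit, and so no size can be read from that step, and no measured change at this place has yet produced a number. The expected step is therefore none beyond the scatter, estimated as a number no higher from compound 1 to compound 3 (the limit leaves the size open) in either direction. In this assay the estimate for compound 3 is 100000 nM with an expected range from 40000 nM to 200000 nM and a report as a limit alone is quite likely.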

Compound 3, half-maximal inhibitory concentration: > 100000 nM
Compound 3: only a limit was reported (the forecaster's own chance of this, stated with the estimate: 75%); the middle value lies on the limit itself.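

Compound 3 stops at a limit, as compound 1 and compound 2 do, so no step among these three compounds can be read in this assay: the limit of > 100000 nM in this assay, at which 3 of the 3 values shown sit.

The compounds shown leave open whether any side group at this place, on the shared core, can give a reading that is a number rather than a limit.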